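Benzyloxy in place of methoxy on the shared core

The compounds below may be only part of what the source reports. "The series", "measured", "known", "first", "only" and "open" are said of these compounds alone.

Measured so far:
compound 1, `CCOC(=O)c1sc(-c2ccccn2)nc1N1CCC(NCc2ccccc2)CC1`, 14.6%;
compound 2, `CCOC(=O)c1sc(-c2ccccn2)nc1N1CCC(NCc2ccc(OC)cc2)CC1`, 4.62%.

Both compounds share one core and differ only in the group on the outer aromatic ring. In an ADME assay on RAW264.7 cells (Mus musculus) for cytotoxicity, read by MTT assay, with a stated time of 72 h, tested at 50 uM (on this read-out higher numbers stand for more inhibition at the one concentration tested (going by the name of the read-out) and lower numbers for less inhibition), compound 2 gives the lower of the two numbers, and its nearest neighbour is compound 1, yet the step of a number 10 percentage points lower from compound 1 to compound 2 (within the scatter) lies within the scatter, so the two compounds cannot be told apart on this read-out.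

Compound 3, `CCOC(=O)c1sc(-c2ccccn2)nc1N1CCC(NCc2ccc(OCc3ccccc3)cc2)CC1`, has not yet been measured. It differs from compound 2 by phenyl in place of hydrogen on a saturated chain carbon bound to an oxygen on an aromatic ring, so that the methoxy becomes a benzyloxy. Among the measured compounds shown here, the only measured step that touches this position is a number 10 percentage points lower from compound 1 to compound 2 (within the scatter), where a methoxy entered in place of hydrogen and the number stayed within the scatter. For the measured compounds named here, nothing measured shows a step beyond the scatter at this position, and no compound with a benzyloxy has been tested. The expectation for compound 3 is therefore a step of a number 7.4 percentage points higher from compound 2 to compound 3 (within the scatter) that stays within the scatter, with a wide range to allow for the larger group. Compound 3 is estimated at 12%, between 0% and 35%.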

Compound 3, a percentage reported as inhibition, at one concentration (the size of the read-out at that concentration, not a potency): 12.8%
For compound 3 the middle estimate is 0.8 percentage points below the measured one; the range from low to high includes it.
By their numbers in this assay, from the lowest: compounds 2, 3 and 1 (each within the scatter of the next).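

Compound 3 adds a phenyl of 6 heavy atoms to the methoxy, and in this assay even this much larger benzyloxy keeps the number inside the scatter (a number 8.2 percentage points higher from compound 2 to compound 3 (within the scatter)). Compared directly with the unsubstituted ring of compound 1, the benzyloxy also stays inside the scatter (a number 1.8 percentage points lower from compound 1 to compound 3 (within the scatter)), so hydrogen, methoxy and benzyloxy on this aromatic carbon cannot be told apart. The position therefore accepts an added aromatic ring with no readable shift at the one concentration tested, a wider reach of change than the methoxy alone could show, though nothing available explains why the numbers stay together.

Open, as far as these compounds go, is whether a group of a different kind on the same aromatic carbon, such as an amine or a carboxylic acid, would carry the number beyond the scatter. Also open, from the compounds shown here alone, is whether a phenyl held on a longer chain, rather than on the single carbon of the benzyloxy, would read the same way.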